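Removing a Ring Chlorine: What to Expect for Compound 4

The source may report more compounds than this note shows. Statements on the series, on what has been measured and on what is new or still open speak of the compounds shown alone.

Measured so far in an assay on CHO-K1 cells for displacement of a labelled ligand from prostaglandin E2 receptor EP1 subtype (Homo sapiens); on this read-out lower numbers stand for stronger inhibition and higher numbers for weaker inhibition:
compound 1 `Cc1cc(C(=O)O)nn1Cc1cc(Br)ccc1OCc1ccccc1` gives 6.46 nM
compound 2 `Cc1cc(C(=O)O)nn1Cc1cc(Br)ccc1OCc1ccc(Cl)cc1` gives 8.71 nM
compound 3 `Cc1cc(C(=O)O)nn1Cc1cc(Cl)ccc1OCc1ccc(Cl)cc1Cl` gives only a limit of the assay, < 2000 nM

Compound 4 `Cc1cc(C(=O)O)nn1Cc1ccccc1OCc1ccc(Cl)cc1Cl` has not yet been measured in this assay. It differs from compound 3 by hydrogen in place of chloro on an aromatic carbon. A change of the same kind, not the same, separates compound 2 from compound 1: hydrogen in place of chloro on an aromatic carbon. There the measured step was a 1.3-fold lower number from compound 2 to compound 1 (0.13 log units; within the scatter). The two places differ: in compound 3 the chlorine sits meta to a large group as well as para to one, whereas in compound 2 it sits only para to a large group. How the core of compound 3 differs from that of compound 2 is not broken down here.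

Compound 4 is expected near 300 nM. The expected range for compound 4 is 30 nM to 3000 nM. For compound 4 this expectation means a step that the limit leaves unreadable from compound 3 to compound 4. For compound 4 the expectation rests on a 1.3-fold lower number from compound 2 to compound 1 (0.13 log units; within the scatter), a change of the same kind that barely moved the value, while compound 3 offers only a limit as a starting point.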

Compound 4, half-maximal inhibitory concentration: < 2000 nM
Compound 4: only a limit was reported; the forecaster's own chance of this, stated with the estimate: 30%; the middle value is on the limit's open side.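

Compound 3 and compound 4 both sit at an assay limit, so no step can be read between them: the limit of < 2000 nM in this assay, at which 2 of the 4 values shown sit.

The compounds shown leave open whether this assay responds at all to hydrogen in place of chloro in this pair.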